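From isopropyl to 3-methylbut-2-en-1-yl on the shared core

The compounds below may be only part of what the source reports. "The series", "measured", "known", "first", "only" and "open" are said of these compounds alone.

In a toxicity assay on CCRF-CEM cells (Homo sapiens) for cytotoxicity (on this read-out lower numbers stand for higher toxicity in this test and higher numbers for lower toxicity in this test), compound 1 `CN(C)c1cccc2c1nc(-c1c(F)cccc1F)n2Cc1c(F)cccc1F` reads > 100 uM, which is a limit of the assay. Within the data shown here, compound 2 `CC(C)c1cccc2c1nc(-c1c(F)cccc1F)n2Cc1c(F)cccc1F` gives 27 uM, the only actual number so far. Compound 3 `CC(C)=CCc1cccc2c1nc(-c1c(F)cccc1F)n2Cc1c(F)cccc1F` carries 3-methylbut-2-en-1-yl in place of isopropyl on an aromatic carbon. Among the measured compounds shown here, the one measured step, an at least 3.7-fold lower number from compound 1 to compound 2 (0.56 log units; beyond the scatter), concerns a different exchange and starts from the limit of > 100 uM in this assay, at which 1 of the 2 values shown sits, so it offers only a loose guide. The expected change is small and stays within the scatter: a 1.2-fold lower number from compound 2 to compound 3 (0.09 log units; within the scatter). For compound 3 the estimated value is 22 uM, with an expected range of 8 uM to 70 uM.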

Compound 3, half-maximal toxic concentration: 28.3 uM
Beside the measured number, compound 3's estimate is 1.3-fold (0.11 log units) below it, and the stated range covers the measured number.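

In this assay, 3-methylbut-2-en-1-yl and isopropyl on this aromatic carbon cannot be told apart, with a 1.0-fold higher number from compound 2 to compound 3 (0.02 log units; within the scatter). The lower number first seen with isopropyl in place of dimethylamino thus also appears with a second carbon group, with an at least 3.5-fold lower number from compound 1 to compound 3 (0.54 log units; beyond the scatter). That step starts from compound 1, whose value is a limit of the assay: the limit of > 100 uM in this assay, at which 1 of the 3 values shown sits.

Whether carbon groups in general give this result stays open, since only these two are shown at this position. From the compounds shown here alone, what a primary amine, a carboxylic acid or a longer alkyl chain would give there also remains open.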